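The compounds below may be only part of what the source reports. "The series", "measured", "known", "first", "only" and "open" are said of these compounds alone.

For the measured compounds named here, in a functional assay on SK-OV-3 cells (Homo sapiens) for cytotoxicity (on this read-out higher numbers stand for weaker inhibition of growth and lower numbers for stronger inhibition of growth), three compounds with the shared core have numbers so far. Compound 2 `CSc1ccc(C2=C(c3ccc(C)c(C)c3)C(=O)N3CCCC3C2)cc1` gives 300 nM, the lowest of the three. Compound 3 `COc1ccc(C2=C(c3ccc(SC)cc3)CC3CCCN3C2=O)cc1OC` gives 9000 nM and compound 1 `COc1ccc(C2=C(c3ccc(SC)cc3)CC3CCCN3C2=O)cc1OC(=O)C1CCCN1C(=O)OC(C)(C)C` gives 10000 nM. Each of these two lies beyond the scatter from compound 2, and they lie within the scatter of each other.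

The next compound is compound 4 `CSc1ccc(C2=C(c3ccc(O)cc3)C(=O)N3CCCC3C2)cc1`, with 4-hydroxyphenyl in place of 3,4-dimethylphenyl on a double-bonded ring carbon. The 4-(methylsulfanyl)phenyl group stays in place.

Going by the values given here, no measured pair isolates this change, so the evidence is indirect. Compound 3, which also carries oxygen on the aryl group at this place, gives 9000 nM. A step to a higher number in this assay, beyond the scatter, is therefore expected, though probably not the whole of that gap. The estimated move is a 3.3-fold higher number from compound 2 to compound 4 (0.52 log units; beyond the scatter). The expected value for compound 4 is 1000 nM, with an estimated range of 200 nM to 5000 nM.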

Compound 4, concentration for 50% growth inhibition: > 100000 nM
Compound 4 gave a limit, no number; the forecaster's own chance of this, stated with the estimate: 10%; middle value at least 100-fold (2.00 log units) away from the limit.
By their numbers in this assay, from the lowest: compound 2; then compounds 3 and 1 (each within the scatter of the next). At a limit, above all of these: compound 4.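

Compound 4 gives > 100000 nM in this assay, which is a limit of the assay and not a number. For the compounds shown here, this is the first pair that differs in one place, and 4-hydroxyphenyl in place of 3,4-dimethylphenyl on the double-bonded ring carbon gives an at least 330-fold higher number from compound 2 to compound 4 (2.52 log units; beyond the scatter). Keeping the 4-(methylsulfanyl)phenyl group is therefore not enough to retain the growth inhibition seen with compound 2, so the aryl group at this place matters strongly, though the full size of the step remains unknown: the limit of > 100000 nM in this assay, at which 1 of the 4 values shown sits.

The pair cannot separate the effect of adding the hydroxy group from that of removing the two methyl groups. A single methyl group on the phenyl ring, or an amine or a carboxylic acid in place of the hydroxy group, would show how narrow the tolerance at this place is.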